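Benzyl replacements at the quinolone core: step to imidazolylmethyl

The source may report more compounds than this note shows. Statements on the series, on what has been measured and on what is new or still open speak of the compounds shown alone.

Measured in a functional assay on P388 cells (Mus musculus) for cytotoxicity; a lower number here means a stronger inhibitor, a higher number a weaker inhibitor:
- compound 1 `Cc1cc(-c2c(F)cc3c(=O)c(Cc4c(O)cccc4O)cn(C4CC4)c3c2F)cc(C)n1`: 250 nM
- compound 2 `Cc1cc(-c2c(F)cc3c(=O)c(Cc4ccccc4O)cn(C4CC4)c3c2F)cc(C)n1`: 670 nM
- compound 3 `Cc1cc(-c2c(F)cc3c(=O)c(Cc4ccc(O)cc4)cn(C4CC4)c3c2F)cc(C)n1`: 1500 nM

Compound 1 gives the lowest number of the three, with compound 2 nearest (a 2.7-fold higher number from compound 1 to compound 2 (0.43 log units; beyond the scatter)) and compound 3 furthest (a 6.0-fold higher number from compound 1 to compound 3 (0.78 log units; beyond the scatter)). Between the two mono-hydroxy analogues the step is a 2.2-fold higher number from compound 2 to compound 3 (0.35 log units; beyond the scatter). Every change so far that removes or moves a hydroxy from the 2,6-dihydroxyphenyl of compound 1 has raised the number in this assay beyond the scatter.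

The next compound is compound 4 `Cc1cc(-c2c(F)cc3c(=O)c(Cc4c[nH]cn4)cn(C4CC4)c3c2F)cc(C)n1`, which differs from compound 1 as follows: 1H-imidazol-4-yl in place of 2,6-dihydroxyphenyl on a saturated chain carbon bound to an aromatic carbon. For the measured compounds named here, no measured step removes both hydroxy groups or brings in a five-membered aromatic ring with 2 hetero atoms, so the two hydroxy-trimming steps are the only guide. Since the loss of a single hydroxy already costs a 2.7-fold higher number from compound 1 to compound 2 (0.43 log units; beyond the scatter), a step of similar or somewhat larger size toward a higher number is expected here, a 3.0-fold higher number from compound 1 to compound 4 (0.48 log units; beyond the scatter), with wide uncertainty. Compound 4 is therefore estimated at 750 nM, in the range 250 nM to 2500 nM.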

Compound 4, half-maximal inhibitory concentration: 390 nM
Compound 4: the middle estimate sits 1.9-fold (0.28 log units) above what was measured, and the stated range covers the measured number.
By their numbers in this assay, from the lowest: compounds 1, 4 and 2 (each within the scatter of the next, the first and the last beyond it); then compound 3.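

In this assay, (1H-imidazol-4-yl)methyl and 2,6-dihydroxybenzyl cannot be told apart at this position, with a 1.6-fold higher number from compound 1 to compound 4 (0.19 log units; within the scatter) for this exchange, and the 2-hydroxyphenyl analogue likewise gives a 1.7-fold lower number from compound 2 to compound 4 (0.24 log units; within the scatter) on the same kind of change. The exchange from the 4-hydroxyphenyl analogue gives a 3.8-fold lower number from compound 3 to compound 4 (0.59 log units; beyond the scatter) and is the only new step beyond the scatter, so among these compounds a hydroxy-bearing phenyl ring is not needed on the saturated chain carbon, and a five-membered aromatic ring with 2 hetero atoms serves there as well. No measurement accompanies these steps that would explain them.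

On these data alone, whether both ring nitrogens of the imidazole are needed remains open, as a pyrazole, a thiazole or a plain phenyl at this place would test. Also open, as far as these compounds go, is how an amine, a carboxylic acid or a longer chain between the core and the ring would behave.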